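Benzylsulfanyl variant in a thioether cytotoxicity series

A few compounds are considered here, and "the series" means these few. Any claim that something is new, unique, unknown or untested is made for them only; others in the source may bear on it.

compound 1 `CNc1nc(N)nc2c1ncn2/C=C1/CC1(CO)CO` — limit, > 20000 nM
compound 2 `CCCSc1nc(N)nc2c1ncn2/C=C1/CC1(CO)CO` — limit, > 20000 nM
compound 3 `CCCCCCSc1nc(N)nc2c1ncn2/C=C1/CC1(CO)CO` — limit, > 20000 nM

In an ADME assay on MOLT-3 cells (Homo sapiens) for cytotoxicity, with a stated time of 7 days (a lower number here means that less compound is tolerated, a higher number that more compound is tolerated), compound 2 gives only a limit, > 20000 nM. Compound 4 `Nc1nc(SCc2ccccc2)c2ncn(/C=C3/CC3(CO)CO)c2n1` differs from it at one place: phenyl in place of ethyl on a saturated chain carbon bound to a sulfur. For the measured compounds named here, the steps that bear on this change are a step that the two limits leave unreadable from compound 2 to compound 3, a step that the two limits leave unreadable from compound 1 to compound 2 and a step that the two limits leave unreadable from compound 1 to compound 3; none of them has a readable size because of the limit of > 20000 nM in this assay, at which 3 of the 3 values shown sit. Going by the values given here, no measured step in this assay therefore gives a direction or a size to expect for the phenyl-for-ethyl change on the sulfur chain. Compound 4 is estimated to sit at 40000 nM, with a range from 12000 nM to 150000 nM; the step that the limit leaves unreadable from compound 2 to compound 4 is expected to stay unreadable.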

Compound 4, half-maximal cytotoxic concentration: > 20000 nM
Compound 4 gave a limit, no number; the forecaster's own chance of this, stated with the estimate: 80%; the middle value does not contradict the limit.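

In this assay, no step can be read between compound 4 and compound 1, compound 2 or compound 3: the limit of > 20000 nM in this assay, at which 4 of the 4 values shown sit.

Going by these compounds, whether these four compounds differ at all, and at what concentration each stops being tolerated, remains open.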